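The compounds below may be only part of what the source reports. "The series", "measured", "known", "first", "only" and "open" are said of these compounds alone.

Of the compounds shown here, three carrying a shared core have been tested in an assay on isolated protein for inhibition of Aromatase (Homo sapiens), read by ELISA, using NADPH, with a stated time of 24 h; on this read-out lower numbers stand for stronger inhibition and higher numbers for weaker inhibition. Compound 1, `Fc1ccc2c(Cn3ccnc3)c(-c3ccc(Cl)cc3)[nH]c2c1`, gives 82.9 nM. Compound 2, `Clc1ccc(-c2[nH]c3cc(Cl)ccc3c2Cn2ccnc2)cc1`, gives 261 nM. Compound 3, `Fc1ccc(-c2[nH]c3cc(F)ccc3c2Cn2cncn2)cc1`, gives 54.4 nM; against compound 1 this lies within the usual scatter, while against compound 2 it lies beyond it. The difference between the cores of compound 1 and compound 3 is not broken down here.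

One change is seen twice among these compounds. From compound 1 to compound 2 the change is chloro in place of fluoro on an aromatic carbon, and it produced a 3.1-fold higher number from compound 1 to compound 2 (0.50 log units; beyond the scatter). Compound 4, `Fc1ccc2c(Cn3cncn3)c(-c3ccc(Cl)cc3)[nH]c2c1`, has not been measured yet; it arises from compound 3 by chloro in place of fluoro on an aromatic carbon. This is the same kind of change as the earlier one, but not the same: in the first case the place is part of a fused or bridged system of two rings, meta to a fused ring and para to a fused ring, whereas in the second case the place is on a six-membered aromatic ring of carbon only, para to a large group.

Because compound 2 showed a 3.1-fold higher number from compound 1 to compound 2 (0.50 log units; beyond the scatter), a somewhat higher number is expected for compound 4 too, though the different surroundings of the place leave the size uncertain, so the expected step is a 1.8-fold higher number from compound 3 to compound 4 (0.26 log units; within the scatter). Compound 4 is therefore estimated at 100 nM, most likely between 45 nM and 250 nM.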

Compound 4, half-maximal inhibitory concentration: 217 nM
The estimate for compound 4 lay 2.2-fold (0.34 log units) below the measured number, within the range that was stated.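

In this assay the swap of fluoro for chloro on the 4-fluorophenyl group gave a 4.0-fold higher number from compound 3 to compound 4 (0.60 log units; beyond the scatter), and this matches in direction and size the same kind of swap made at a different place on a different core: the same change on two cores in this assay, a 3.1-fold higher number (0.50 log units; beyond the scatter) from compound 1 to compound 2 and a 4.0-fold higher number (0.60 log units; beyond the scatter) from compound 3 to compound 4, 1.3-fold (0.10 log units) apart, within the scatter of two such steps. So within this series the penalty for the swap carried over from one core to the other, although these are only two pairs of compounds, and they show neither why the number rises nor whether the step would hold on a core outside this small set. A separate change, 1H-1,2,4-triazol-1-yl in place of 1H-imidazol-1-yl on the saturated chain carbon, gave a 2.6-fold higher number from compound 1 to compound 4 (0.42 log units; beyond the scatter), but this comparison rests on a single pair, so it cannot yet be said whether that step would carry over in the same way.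

The compounds shown leave open whether the same change of the ring on the chain would give a similar step on a core carrying fluoro on the phenyl group. They also leave open what a bromo or a methoxy group would do in place of the chloro of the 4-chlorophenyl group.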